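This account rests on a few compounds, and the source may have more. Where it says the series, first, only, none or still open, it means among the compounds named here.

Going by the values given here, compound 2 `Oc1ccc(-c2cc(-c3ccco3)cc(-c3ccccc3O)n2)cc1` is the only compound with a reported number: in an assay on isolated protein for inhibition of DNA topoisomerase 1 (Homo sapiens), with a stated time of 30 min, tested at 20 uM (a lower number here means a weaker effect, a higher number a stronger effect of the compound at the concentration tested), compound 2 gives 0%. Compound 1 `Oc1ccc(-c2cc(-c3ccsc3)cc(-c3cccc(O)c3)n2)cc1` was entered in this assay, but for compound 1 the entry reads "not determined" (no result reported), so no result was reported for it. Compound 3 `Oc1ccc(-c2cc(-c3ccco3)cc(-c3cccc(O)c3)n2)cc1` differs from compound 2 in one place: 3-hydroxyphenyl in place of 2-hydroxyphenyl on an aromatic carbon. Among the compounds with values here, no step between two measured compounds is available, so the effect of this change cannot be read from earlier pairs. Because compound 2 shows 0%, the step of a number 5 percentage points higher from compound 2 to compound 3 (within the scatter) is expected to stay within the scatter. Compound 3 is therefore estimated to give 5% in this assay, with a range from 0% to 20%.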

Compound 3, a percentage reported as inhibition, at one concentration (the size of the read-out at that concentration, not a potency): 1.5%
For compound 3 the middle estimate is 3.5 percentage points above the measured one; low and high end bracket the measured number.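

Replacing 2-hydroxyphenyl with 3-hydroxyphenyl on the aromatic carbon next to the ring nitrogen gives a number 1.5 percentage points higher from compound 2 to compound 3 (within the scatter) in this assay. In this single pair, then, moving the hydroxyl around that phenyl ring produces no difference that can be told from the scatter. Nothing available here offers an explanation for this result. Going by these compounds alone, compound 1 has no reported result, so no step involving it can be read. On these data alone, whether an amine or a carboxylic acid in place of the hydroxyl would give a clearer read-out remains open.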